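Swapping the Sulfonamide Cap in a Thiourea Series

The compounds below may be only part of what the source reports. "The series", "measured", "known", "first", "only" and "open" are said of these compounds alone.

Two measured compounds share the same core and differ only in the group attached to a sulfonamide nitrogen. Compound 1 `CC(=O)NS(=O)(=O)c1ccc(N/C(S)=N\c2ccnc3cc(C(F)(F)F)ccc23)cc1` carries an acetyl there; in a functional assay on HT-1080 cells (Homo sapiens) for antiproliferative activity, read by sulforhodamine B assay, with a stated time of 48 h (on this read-out lower numbers stand for stronger inhibition and higher numbers for weaker inhibition), compound 1 gives 28300 nM. Compound 2 `Cc1cc(C)nc(NS(=O)(=O)c2ccc(N/C(S)=N\c3ccnc4cc(C(F)(F)F)ccc34)cc2)n1` carries a 4,6-dimethylpyrimidin-2-yl instead, and in this assay compound 2 gives 29500 nM. The step of a 1.0-fold higher number from compound 1 to compound 2 (0.02 log units; within the scatter) shows that this exchange left the read-out essentially unchanged. Among the two numbers, compound 1 has the lowest, but its only neighbour lies within the scatter, so no order between the two can be claimed.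

Compound 3 `COc1cc(NS(=O)(=O)c2ccc(N/C(S)=N\c3ccnc4cc(C(F)(F)F)ccc34)cc2)nc(OC)n1` has not yet been measured. Its difference from compound 1 is 2,6-dimethoxypyrimidin-4-yl in place of acetyl on a sulfonamide nitrogen. This resembles the change leading to compound 2: once more a six-membered aromatic ring with two hetero atoms replaces the acetyl on a sulfonamide nitrogen. A step within the scatter is expected in this assay, namely a 1.0-fold lower number from compound 1 to compound 3 (0.00 log units; within the scatter), because the comparable step a 1.0-fold higher number from compound 1 to compound 2 (0.02 log units; within the scatter) produced no real movement. Compound 3 is therefore estimated at 28000 nM, with a range from 12000 nM to 65000 nM.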

Compound 3, half-maximal inhibitory concentration: 29500 nM
Estimate against measurement, compound 3: 1.1-fold (0.02 log units) below; low and high end bracket the measured number.
By their numbers in this assay, from the lowest: compounds 1, 2 and 3 (each within the scatter of the next).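

The larger 2,6-dimethoxypyrimidin-4-yl, with 10 heavy atoms against the 3 of acetyl, gives a 1.0-fold higher number from compound 1 to compound 3 (0.02 log units; within the scatter) in this assay, so a second ring group on the sulfonamide nitrogen also leaves the read-out where the acetyl compound stands. Exchanging one ring group for the other, 4,6-dimethylpyrimidin-2-yl for 2,6-dimethoxypyrimidin-4-yl, gives no change at the digits printed from compound 2 to compound 3 (within the scatter), which shows that neither the different ring substituents nor the different point of attachment produce a readable difference between these two compounds. All three groups on this nitrogen therefore give numbers within the scatter of one another, and no measurement shown here explains why the read-out stays so flat across them.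

From the compounds shown here alone, what remains open is whether anything placed on this nitrogen can move the number at all, since acetyl and the two substituted pyrimidine groups give no contrast to work from. A plain hydrogen, a small methyl, or a longer chain ending in an amine or a carboxylic acid at this position would test whether the sulfonamide cap matters to the read-out.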